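A few compounds are considered here, and "the series" means these few. Any claim that something is new, unique, unknown or untested is made for them only; others in the source may bear on it.

Of the compounds shown here, three with a shared core have been measured. In a functional assay on HCT-116 cells (Homo sapiens) for antiproliferative activity, read by MTT assay, with a stated time of 72 h (on this read-out higher numbers stand for weaker inhibition and lower numbers for stronger inhibition), compound 1 `Cc1ccc(OCCCON2C(N)=NC(N)=NC23CCOCC3)cc1` gives 2390 nM. Compound 2 `NC1=NC2(CCOCC2)N(OCCCOc2ccccc2Br)C(N)=N1` gives 30 nM in this assay, and compound 3 `COc1ccc(OCCCON2C(N)=NC(N)=NC23CCOCC3)cc1` gives 1500 nM. Among these three numbers compound 3 holds the second highest; its nearest neighbour is compound 1, since the step of a 1.6-fold lower number from compound 1 to compound 3 (0.20 log units; within the scatter) lies within the scatter, while the step of a 50-fold higher number from compound 2 to compound 3 (1.70 log units; beyond the scatter) lies far beyond it.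

Compound 4 `NC1=NC2(CCOCC2)N(OCCCOc2ccccc2)C(N)=N1` has not yet been measured in this assay. It differs from compound 3 in one place: hydrogen in place of methoxy on an aromatic carbon. Among the measured compounds shown here, the only measured step that bears on this kind of change is a 1.6-fold lower number from compound 1 to compound 3 (0.20 log units; within the scatter), which swapped methoxy for methyl on the same aromatic carbon and stayed within the scatter. The large steps of an 80-fold lower number from compound 1 to compound 2 (1.90 log units; beyond the scatter) and a 50-fold higher number from compound 2 to compound 3 (1.70 log units; beyond the scatter) concern the 2-bromophenyl and say nothing about removing the methoxy. The step of a 1.3-fold higher number from compound 3 to compound 4 (0.12 log units; within the scatter) is therefore expected to stay within the scatter. Compound 4 is estimated at 2000 nM, with a range from 800 nM to 5000 nM.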

Compound 4, half-maximal inhibitory concentration: 6010 nM
For compound 4 the middle estimate is 3.0-fold (0.48 log units) below the measured one; the whole stated range lies below it.
By their numbers in this assay, from the lowest: compound 2; then compounds 3 and 1 (each within the scatter of the next); then compound 4.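

In this assay, the unsubstituted phenyl does not match the substituted rings: a 4.0-fold higher number from compound 3 to compound 4 (0.60 log units; beyond the scatter) and a 2.5-fold higher number from compound 1 to compound 4 (0.40 log units; beyond the scatter) both lie beyond the scatter. On the aromatic carbon para to a large group, methoxy and methyl therefore each give a lower number than hydrogen, something the earlier methyl-to-methoxy step, which stayed within the scatter, could not show. With the phenyl as the reference, the 2-bromophenyl stands much further off, as a 200-fold higher number from compound 2 to compound 4 (2.30 log units; beyond the scatter) is a far larger step than the other two.

Nothing available explains why hydrogen differs from these groups. Going by these compounds, it remains open whether an amine or a carboxylic acid on that same carbon would fall in with methyl and methoxy, and whether a longer chain would keep the lower number.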